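Aryl variation on the shared core: expected inhibition of compound 4

The source may report more compounds than this note shows. Statements on the series, on what has been measured and on what is new or still open speak of the compounds shown alone.

Measured compounds
Compound 1 `O=Cc1ccc(-c2cn3ccnc3c(-c3ccc4ncn(C5CCCCC5)c4c3)n2)cc1` — in a functional assay on SK-MEL-5 cells (Homo sapiens) for inhibition, read by sulforhodamine B assay, with a stated time of 48 h, tested at 10 uM (a higher number here means more inhibition at the concentration tested (going by the name of the read-out), a lower number less inhibition), compound 1 gives 56.5%
Compound 2 `CC(=O)c1ccc(-c2cn3ccnc3c(-c3ccc4ncn(C5CCCCC5)c4c3)n2)cc1` — in this assay compound 2 gives 24.8%
Compound 3 `Fc1ccccc1-c1cn2ccnc2c(-c2ccc3ncn(C4CCCCC4)c3c2)n1` — in this assay compound 3 gives 6.5%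

Compound 3 is the lowest of the three measured in this assay; the steps to it, a number 50 percentage points lower from compound 1 to compound 3 (beyond the scatter) and a number 18.3 percentage points lower from compound 2 to compound 3 (beyond the scatter), are both beyond the scatter, as is a number 31.7 percentage points lower from compound 1 to compound 2 (beyond the scatter) between the two others. Every measured step changes the aryl ring on the shared core, so this ring clearly moves the read-out, though in which direction a given replacement goes cannot be read from three points.

Compound 4 `FC(F)(F)c1cccc(-c2cn3ccnc3c(-c3ccc4ncn(C5CCCCC5)c4c3)n2)c1` differs from compound 3 by 3-(trifluoromethyl)phenyl in place of 2-fluorophenyl on an aromatic carbon. Within the data shown here, no measured step involves a trifluoromethyl group or a substituent in this position, so the bearing of the known steps is only indirect: they show that such changes can be large. Among the measured compounds shown here, with no direct precedent the working assumption is a small shift upward from the low value of compound 3, well inside a broad range; the expected step is a number 5.5 percentage points higher from compound 3 to compound 4 (within the scatter). For compound 4 the estimate in this assay is 12%, between 0% and 35%.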

Compound 4, a percentage reported as inhibition, at one concentration (the size of the read-out at that concentration, not a potency): 4.32%
Beside the measured number, compound 4's estimate is 7.7 percentage points above it; the range from low to high includes it.
By their numbers in this assay, from the lowest: compounds 4 and 3 (each within the scatter of the next); then compound 2; then compound 1.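

In this assay, replacing 2-fluorophenyl with 3-(trifluoromethyl)phenyl on this aromatic carbon gives a number 2.2 percentage points lower from compound 3 to compound 4 (within the scatter), so the two fluorine-bearing aryl groups cannot be told apart here. Against the carbonyl-bearing aryl groups, the change gives a number 20.5 percentage points lower from compound 2 to compound 4 (beyond the scatter) and a number 52.2 percentage points lower from compound 1 to compound 4 (beyond the scatter); among the four compounds, the two fluorine-bearing groups now form a low pair, and no compound shown goes against this split. Nothing available explains the split.

Going by these compounds, it remains open whether the carbonyl itself goes with the higher numbers or whether other groups at the same ring position would do as well. A phenyl ring carrying a carboxylic acid or an amine in place of the formyl group would test this directly.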